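The compounds below may be only part of what the source reports. "The series", "measured", "known", "first", "only" and "open" are said of these compounds alone.

Compound 1 `CCc1nc(C)c2cnnc(SC)n12` is one of three compounds whose inhibition has been measured in a functional assay for inhibition, with Homo sapiens as the target; a higher number here means a weaker inhibitor, a lower number a stronger inhibitor. In this assay compound 1 gives > 48000 nM, which is a limit of the measurement and not a number. Compound 2 `CCCc1nc(C)c2cnn(CC(O)CO)c(=O)n12` gives > 48000 nM, also a limit. Compound 3 `CCCc1nc(C)c2c(-c3ccccc3)nnc(O)n12` gives > 48000 nM, again a limit. Compound 1 therefore stands at the limit of > 48000 nM in this assay, at which 3 of the 3 values shown sit, together with the other two, and because every value is a limit no measured step between any pair of these compounds can be read.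

Compound 4 `CSc1nncc2c(C)ncn12` has not yet been measured. It differs from compound 1 in one place: hydrogen in place of ethyl on an aromatic carbon, while the rest of the structure is unchanged. Going by the values given here, no measured step of this kind exists among the three compounds, so the size of the change cannot be taken from a measured pair. The step that the limit leaves unreadable from compound 1 to compound 4 is expected to be no larger than the usual scatter, with no direction favored, because compound 1 already sits at the limit of > 48000 nM in this assay, at which 3 of the 3 values shown sit. Compound 4 is accordingly expected to give about 60000 nM in this assay, within a range from 20000 nM to 200000 nM, and most probably again only as a limit.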

Compound 4, half-maximal inhibitory concentration: > 48000 nM
Compound 4: only a limit was reported; the forecaster's own chance of this, stated with the estimate: 85%; the middle value is on the limit's open side.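

The step from compound 1 to compound 4, hydrogen in place of ethyl on an aromatic carbon, cannot be read, because both compounds carry only a limit, as does every other compound shown: the limit of > 48000 nM in this assay, at which 4 of the 4 values shown sit.

The compounds shown leave open which groups on the shared core, if any, would give a real number rather than a limit in this assay.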